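The source may hold more compounds than are shown below. What is called first, only, known or untested is meant among the compounds shown, and "the series" means these compounds.

Compound 1, `NNc1nc2ccc(Br)cc2s1`: 8.01 ug/mL
Compound 2, `O=[N+]([O-])c1ccc(-c2nnc(-c3cccnc3)n2Nc2nc3ccc(F)cc3s2)cc1`: >= 108 ug/mL

Both compounds were tested in an ADME assay on MT4 cells (Homo sapiens) for cytotoxicity, read by MTT assay, with a stated time of 5 days; on this read-out higher numbers stand for lower toxicity in this test and lower numbers for higher toxicity in this test. In this assay compound 1 gives 8.01 ug/mL. For compound 2 the read-out is only a limit of the assay, >= 108 ug/mL. Compound 2 therefore sits at the limit of >= 108 ug/mL in this assay, at which 1 of the 2 values shown sits. Among the compounds with values here, the two compounds differ in many places at once, so no single step between them can be traced; all that can be said is that compound 2 reached the limit while compound 1 returned a number.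

Compound 3, `Cc1cccc2sc(Nn3c(-c4ccc([N+](=O)[O-])cc4)nnc3-c3cccnc3)nc12`, has not yet been measured. It differs from compound 2 in one place: 4-methyl-1,3-benzothiazol-2-yl in place of 6-fluoro-1,3-benzothiazol-2-yl on a nitrogen on an aromatic ring. Within the data shown here, no pair of measured compounds shows what this change does in this assay. With compound 2 already at the limit, the step from compound 2 to compound 3 is expected to be small, in either direction, or none beyond the scatter, and the estimate means a step of a number no higher from compound 2 to compound 3 (the limit leaves the size open). The read-out for compound 3 may again be a limit rather than a number. Compound 3 is expected to give about 108 ug/mL, within a range from 50 ug/mL to 200 ug/mL.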

Compound 3, half-maximal cytotoxic concentration: 13.5 ug/mL
Compound 3: the middle estimate sits 8.0-fold (0.90 log units) above what was measured; measured number below the stated range.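

In this assay, within the data shown here, putting 4-methyl-1,3-benzothiazol-2-yl in place of 6-fluoro-1,3-benzothiazol-2-yl on a nitrogen on an aromatic ring gives an at least 8.0-fold lower number from compound 2 to compound 3 (0.90 log units; beyond the scatter), the first change in one place that can be read here. A lower number means higher toxicity in this test, so this position matters for the read-out, even though the two groups have the same counts of heavy atoms, rings, hydrogen-bond donors and hydrogen-bond acceptors. Compound 2 stands at a limit and not at a number, so the size of the step remains open on one side: the limit of >= 108 ug/mL in this assay, at which 1 of the 3 values shown sits.

The swap removes the fluorine and adds the methyl in one move, so the compounds shown cannot say which of the two goes with the lower number, or whether both do. A plain 1,3-benzothiazol-2-yl group carrying neither fluorine nor methyl would help to separate the two, and an amine or a carboxylic acid on this ring system would show how far the trend reaches beyond these two groups.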